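Expected Cell Tolerance of Compound 4 from Compound 2

The source may hold more compounds than are shown below. What is called first, only, known or untested is meant among the compounds shown, and "the series" means these compounds.

Of the compounds shown here, three sharing one core have been tested in an ADME assay on HEL cells (Homo sapiens) for cytotoxicity; a higher number here means that more compound is tolerated, a lower number that less compound is tolerated. Compound 1 `O=C(COc1cccc2ccccc12)N/N=C/c1ccccc1[N+](=O)[O-]` gives 100 ug/mL. Compound 2 `O=C(COc1cccc2ccccc12)N/N=C/c1ccccc1Cl` gives 62.7 ug/mL in this assay. Compound 3 `C/C(=N\NC(=O)COc1cccc2ccccc12)c1ccc(Br)cc1` gives 15.3 ug/mL in this assay. Among these three numbers compound 2 stands second highest: compound 1 is its nearest neighbour, within the scatter, while compound 3 lies furthest away, beyond the scatter. Going by the values given here, the only step between measured compounds that differ in one place is a 1.6-fold lower number from compound 1 to compound 2 (0.20 log units; within the scatter), which stayed within the scatter.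

Compound 4 `CSc1ccc(/C=N/NC(=O)COc2cccc3ccccc23)cc1` has not yet been measured in this assay. It differs from compound 2 in one place: 4-(methylsulfanyl)phenyl in place of 2-chlorophenyl on a carbon with a double bond to nitrogen. Among the compounds with values here, no measured step exchanges one aromatic ring for another, so the single step that exists, a 1.6-fold lower number from compound 1 to compound 2 (0.20 log units; within the scatter), bears only loosely on this change; it altered one group on the ring and moved the number little. The other ring variant, compound 3, sits beyond the scatter below compound 2, which hints that changing the ring can lower tolerance, though that is one compound only. A modest downward step is therefore expected, perhaps within the scatter. Compound 4 is expected to give 40 ug/mL, with a range from 15 ug/mL to 100 ug/mL, corresponding to an expected step of a 1.6-fold lower number from compound 2 to compound 4 (0.20 log units; within the scatter).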

Compound 4, half-maximal cytotoxic concentration: > 100 ug/mL
Compound 4: a limit, no number; the forecaster's own chance of this, stated with the estimate: 10%; middle value at least 2.5-fold (0.39 log units) away from the limit.
By their numbers in this assay, from the lowest: compound 3; then compounds 2 and 1 (each within the scatter of the next).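

In this assay compound 4 gives > 100 ug/mL, which is a limit of the assay and not a number. Going by these compounds alone, this is the first measured exchange of one whole aromatic ring for another on the carbon with a double bond to nitrogen, and 4-(methylsulfanyl)phenyl in place of 2-chlorophenyl gives an at least 1.5-fold higher number from compound 2 to compound 4 (0.20 log units; that floor lies within the scatter), so in this pair the new ring brings no measurable loss of tolerance, and a larger ring group with a sulfur atom is accepted at this place. Only the floor of the step is known, and that floor does not by itself separate compound 4 from compound 2, because the true size of the step is hidden by the cap on the read-out: the limit of > 100 ug/mL in this assay, at which 1 of the 4 values shown sits.

The compounds shown leave open whether the result follows from the new group or from where it sits on the ring, since the names 2-chlorophenyl and 4-(methylsulfanyl)phenyl differ in both; 4-chlorophenyl at the same place would separate the two. They also leave open whether the sulfur matters, which 4-methoxyphenyl could test, and how a ring carrying an amine or a carboxylic acid would behave here.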